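Trimming the Hydroxyalkyl Chain of a Kinase Inhibitor

The source may hold more compounds than are shown below. What is called first, only, known or untested is meant among the compounds shown, and "the series" means these compounds.

Within the data shown here, compound 2 `CC(C)(O)CNc1cc(Oc2ccc(NC(=O)Nc3cccc(C(F)(F)F)c3)cc2)ncn1` holds the lowest of the two numbers measured so far in an assay on isolated protein for inhibition of serine/threonine-protein kinase TNNI3K (Homo sapiens) (a lower number here means a stronger inhibitor, a higher number a weaker inhibitor), where compound 2 gives 40 nM. Its nearest neighbour is compound 1 `CC(C)CNc1cc(Oc2ccc(NC(=O)Nc3cccc(C(F)(F)F)c3)cc2)ncn1`, which in this assay gives 50 nM; the step of a 1.3-fold lower number from compound 1 to compound 2 (0.10 log units; within the scatter) lies within the scatter. Compound 3 `O=C(Nc1ccc(Oc2cc(NCCO)ncn2)cc1)Nc1cccc(C(F)(F)F)c1` has not yet been measured. It differs from compound 2 by hydroxymethyl in place of 1-hydroxy-1-methylethyl on a saturated chain carbon bound to a nitrogen on an aromatic ring. Among the measured compounds shown here, only one measured step touches this part of the molecule, the one from compound 1 to compound 2, which added the hydroxy group and stayed within the scatter. For the measured compounds named here, no measured pair shows what the loss of the two methyl groups does on its own. One therefore expects only a small step in this assay, estimated as a 1.5-fold higher number from compound 2 to compound 3 (0.18 log units; within the scatter), perhaps a slight weakening but not clearly beyond the scatter. Compound 3 is estimated to give 60 nM in this assay, with a range from 25 nM to 150 nM.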

Compound 3, half-maximal inhibitory concentration: 32 nM
Compound 3: the middle estimate sits 1.9-fold (0.27 log units) above what was measured; the range from low to high includes it.
By their numbers in this assay, from the lowest: compounds 3, 2 and 1 (each within the scatter of the next).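

In this assay, among these compounds, going from 2-hydroxy-2-methylpropyl to 2-hydroxyethyl gives a 1.3-fold lower number from compound 2 to compound 3 (0.10 log units; within the scatter), so this position tolerates the loss of the two methyl groups, which no earlier pair had isolated, without a step beyond the scatter. Hydroxymethyl in place of isopropyl on the same chain carbon gives a 1.6-fold lower number from compound 1 to compound 3 (0.19 log units; within the scatter), which means that the three chains shown cannot be told apart in this assay, with or without the hydroxy group. No independent measurement is available that would account for how close these values lie.

The compounds shown leave open whether an amine or a carboxylic acid in place of the hydroxy group would stay as close to these values. They also leave open whether a longer chain carrying the hydroxy group would do so.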